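A few compounds are considered here, and "the series" means these few. Any claim that something is new, unique, unknown or untested is made for them only; others in the source may bear on it.

Measured in a functional assay on Hs-578T cells (Homo sapiens) for inhibition, read by sulforhodamine B assay, with a stated time of 48 h; on this read-out lower numbers stand for stronger inhibition of growth and higher numbers for weaker inhibition of growth:
- compound 1 `Cc1ccc(C2=NN(c3ccc(S(C)(=O)=O)cc3)C(=O)CC2)cc1`: 460 nM
- compound 2 `Cc1cc(O)ccc1C1=NN(c2ccc(S(C)(=O)=O)cc2)C(=O)CC1`: 4150 nM

Compound 2, at 4150 nM, holds the higher of the two numbers, so it shows the weaker inhibition of growth. Compound 1 is its nearest neighbour. The next compound is compound 3 `CCc1ccc(C2=NN(c3ccc(S(C)(=O)=O)cc3)C(=O)CC2)cc1`, with 4-ethylphenyl in place of 4-hydroxy-2-methylphenyl on a carbon with a double bond to nitrogen.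

Among the measured compounds shown here, only one measured step bears on this change: a 9.0-fold higher number from compound 1 to compound 2 (0.96 log units; beyond the scatter). That step brought in 4-hydroxy-2-methylphenyl in place of 4-methylphenyl, and the present change removes the same group. For the measured compounds named here, no measured compound carries 4-ethylphenyl, so the size of the return is uncertain. A step of similar size towards a lower number is expected in this assay. The expected step is a 7.5-fold lower number from compound 2 to compound 3 (0.88 log units; beyond the scatter). Compound 3 is estimated at 550 nM, with an expected range of 170 nM to 1800 nM.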

Compound 3, concentration for 50% growth inhibition: 830 nM
Estimate against measurement, compound 3: 1.5-fold (0.18 log units) below; low and high end bracket the measured number.
By their numbers in this assay, from the lowest: compounds 1 and 3 (each within the scatter of the next); then compound 2.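

In this assay, the 4-ethylphenyl and 4-methylphenyl groups cannot be told apart on this carbon with a double bond to nitrogen, with a 1.8-fold higher number from compound 1 to compound 3 (0.26 log units; within the scatter). Measured against 4-hydroxy-2-methylphenyl, 4-ethylphenyl gives a 5.0-fold lower number from compound 2 to compound 3 (0.70 log units; beyond the scatter), so among the three compounds the weaker inhibition of growth belongs to compound 2 alone and is not shared by either 4-alkylphenyl compound. Nothing available gives a cause for these differences.

The 4-hydroxy-2-methylphenyl group carries both a hydroxyl and an extra ring methyl, and the compounds shown cannot separate the two, which would take a 4-hydroxyphenyl or a 2-methylphenyl group. Also open, on these data alone, is whether a longer chain such as 4-propylphenyl, or an aminophenyl group, would stay at the level of compound 1 and compound 3.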